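Swapping 3-isopropylphenyl for 4-(tert-butyl)phenyl on the shared core

The compounds below may be only part of what the source reports. "The series", "measured", "known", "first", "only" and "open" are said of these compounds alone.

Of the compounds shown here, three with a shared core have been measured in an ADME assay on L02 cells (Homo sapiens) for inhibition, read by CCK-8 assay, with a stated time of 48 h; a lower number here means a stronger inhibitor of growth, a higher number a weaker inhibitor of growth. Compound 1 `CN1CCN(c2ccc(Nc3ncc(Cl)c(NCc4ccc(C(F)(F)F)cc4)n3)nc2)CC1` gives 26200 nM. Compound 2 `Cc1ccc(CNc2nc(Nc3ccc(N4CCN(C)CC4)cn3)ncc2Cl)cc1` reads > 100000 nM, which is a limit of the assay and not a number. Compound 3 `CC(C)c1cccc(Nc2nc(Nc3ccc(N4CCN(C)CC4)cn3)ncc2Cl)c1` gives 12500 nM, the lowest of the two actual numbers. Its nearest neighbour is separated by a modest gap, a 2.1-fold lower number from compound 1 to compound 3 (0.32 log units; beyond the scatter), while the comparison resting on the limit shows an at least 8.0-fold lower number from compound 2 to compound 3 (0.90 log units; beyond the scatter).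

Compound 4 `CN1CCN(c2ccc(Nc3ncc(Cl)c(Nc4ccc(C(C)(C)C)cc4)n3)nc2)CC1` differs from compound 3 in one place: 4-(tert-butyl)phenyl in place of 3-isopropylphenyl on a nitrogen on an aromatic ring. Among the compounds with values here, no measured step exchanges one substituted phenyl for another. Within the data shown here, two steps touch the same nitrogen, a 2.1-fold lower number from compound 1 to compound 3 (0.32 log units; beyond the scatter) and an at least 8.0-fold lower number from compound 2 to compound 3 (0.90 log units; beyond the scatter), but both replace a benzyl group, whereas compound 4 keeps a phenyl group there, as compound 3 does. The remaining step, an at least 3.8-fold higher number from compound 1 to compound 2 (0.58 log units; beyond the scatter), shows that changing a substituent on an aromatic carbon can move the number, so a wide range is warranted. The expected change is small and could go either way, with a slight lean upward, and the estimate is a 1.1-fold higher number from compound 3 to compound 4 (0.05 log units; within the scatter). For compound 4 the estimated value is 14000 nM, with an expected range from 5000 nM to 40000 nM.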

Compound 4, concentration for 50% growth inhibition: 6070 nM
Compound 4: middle estimate off by 2.3-fold (0.36 log units), on the high side; the measured number falls inside the stated range.
By their numbers in this assay, from the lowest: compound 4; then compound 3; then compound 1. At a limit, above all of these: compound 2.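

In this assay, the exchange of one substituted phenyl for another on this nitrogen moves the number beyond the scatter, with a 2.1-fold lower number from compound 3 to compound 4 (0.31 log units; beyond the scatter), whereas every earlier step at this nitrogen replaced a benzyl group. Compound 4 also widens the distance from the 4-(trifluoromethyl)benzyl compound, with a 4.3-fold lower number from compound 1 to compound 4 (0.64 log units; beyond the scatter), so among the compounds with actual numbers, the two phenyl compounds both sit below the benzyl compound. Compound 2 reads as a limit of the assay and not a number, and the step to it is an at least 16-fold lower number from compound 2 to compound 4 (1.21 log units; beyond the scatter).

Whether 4-isopropylphenyl or 3-(tert-butyl)phenyl on this nitrogen would read closer to compound 3 or to compound 4 stays open, so the compounds shown do not separate the change of alkyl group from the change in where it sits on the phenyl ring. Also open, from the compounds shown here alone, is how a phenyl group carrying an amine or a carboxylic acid in place of the alkyl group would read in this assay.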